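Swapping Propyl for Phenyl on the Triazole Ring

This account rests on a few compounds, and the source may have more. Where it says the series, first, only, none or still open, it means among the compounds named here.

Measured compounds:
compound 1, `C#CCOc1cc(O)c2c(c1)O[C@H](c1ccc(OC)c(O)c1)C/C2=N\O`: 19100 nM
compound 2, `CCCn1cc(COc2cc(O)c3c(c2)O[C@H](c2ccc(OC)c(O)c2)C/C3=N\O)nn1`: 2340 nM

Both were tested in a functional assay on RAW264.7 cells (Mus musculus) for inhibition, read by Griess assay, with stated times of 2 h and 24 h; a higher number here means a weaker inhibitor, a lower number a stronger inhibitor. Among the compounds with values here, compound 2 has the lower of the two numbers; the only measured step, an 8.2-fold lower number from compound 1 to compound 2 (0.91 log units; beyond the scatter), separates it from compound 1 and replaces an ethynyl group with the propyl-bearing triazole ring.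

Compound 3 is `COc1ccc([C@@H]2C/C(=N\O)c3c(O)cc(OCc4cn(-c5ccccc5)nn4)cc3O2)cc1O`. It differs from compound 2 by phenyl in place of propyl on an aromatic nitrogen. Within the data shown here, no measured step touches the group on the triazole nitrogen: the one step known, an 8.2-fold lower number from compound 1 to compound 2 (0.91 log units; beyond the scatter), built the ring itself rather than varying what sits on it, so it gives no guide to the size or direction of this change. With nothing to point either way, the expectation is a step that stays within the usual scatter, a 1.2-fold lower number from compound 2 to compound 3 (0.07 log units; within the scatter). Compound 3 is therefore estimated at 2000 nM, with a plausible range from 700 nM to 6000 nM.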

Compound 3, half-maximal inhibitory concentration: 6130 nM
For compound 3 the middle estimate is 3.1-fold (0.49 log units) below the measured one; the whole stated range lies below it.
By their numbers in this assay, from the lowest: compound 2; then compound 3; then compound 1.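

What sits on the triazole nitrogen does make a difference in this assay and is not just a passive end group: with phenyl in place of propyl there is a 2.6-fold higher number from compound 2 to compound 3 (0.42 log units; beyond the scatter) and so part of the gain seen with the propyl-bearing triazole is lost. The phenyl-bearing triazole still keeps an advantage over the ethynyl group, with a 3.1-fold lower number from compound 1 to compound 3 (0.49 log units; beyond the scatter) so in these three compounds both triazoles give lower numbers than the ethynyl group, and propyl gives the lowest. No measurement shown here explains why propyl and phenyl differ in this way.

Within the data shown here, with only one chain and one ring on this nitrogen, the comparison cannot separate the effect of chain length from that of having a ring. A butyl chain or a benzyl group at the same nitrogen would help to tell which of the two counts.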